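Chloro for Fluoro on the Aromatic Ring: an Expectation

The source may hold more compounds than are shown below. What is called first, only, known or untested is meant among the compounds shown, and "the series" means these compounds.

Measured so far:
Compound 1 `N=C(N)c1ccc(-c2ccc(-c3cncc4ccccc34)s2)s1` gives 1510 nM in a functional assay on KM12 cells (Homo sapiens) for inhibition, read by sulforhodamine B assay, with a stated time of 48 h; on this read-out higher numbers stand for weaker inhibition of growth and lower numbers for stronger inhibition of growth.
Compound 2 `N=C(N)c1ccc(-c2ccc(-c3ccc(F)cc3)o2)o1` gives 1440 nM in this assay.

Compound 2 carries the lowest of the two numbers, but its nearest neighbour, compound 1, sits so close that the gap lies within the scatter of this assay, so neither compound can be called the more potent of the pair. Compound 3 `N=C(N)c1ccc(-c2ccc(-c3ccc(Cl)cc3)o2)o1` is not yet measured; it differs from compound 2 by chloro in place of fluoro on an aromatic carbon. Among the compounds with values here, no step between two measured compounds is available to calibrate this exchange, so the expectation rests only on the value of compound 2, which gives 1440 nM in this assay. The step from the fluoro to the chloro compound is expected to be small, at most a modest gain in growth inhibition, most likely none beyond the scatter, which is the step of a 1.3-fold lower number from compound 2 to compound 3 (0.12 log units; within the scatter). Compound 3 is therefore estimated at 1100 nM in this assay, with a range from 400 nM to 3000 nM.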

Compound 3, concentration for 50% growth inhibition: 1630 nM
The estimate for compound 3 lay 1.5-fold (0.17 log units) below the measured number; low and high end bracket the measured number.
By their numbers in this assay, from the lowest: compounds 2, 1 and 3 (each within the scatter of the next).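

In this assay, within the data shown here, chloro in place of fluoro on an aromatic carbon, para to a large group, gives a 1.1-fold higher number from compound 2 to compound 3 (0.05 log units; within the scatter), the first step in this set that can be read between two compounds differing in one place. At this position, the exchange of fluoro for chloro therefore leaves the two compounds within the scatter, and neither can be ranked above the other. Nothing at hand bears on the reason for this result.

The compounds shown leave open whether a group of another kind at this place, such as an amine or a carboxylic acid, would move the number beyond the scatter. They also leave open whether fluoro and chloro would stay as close to each other on the core of compound 1.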